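A few compounds are considered here, and "the series" means these few. Any claim that something is new, unique, unknown or untested is made for them only; others in the source may bear on it.

Of the compounds shown here, two sharing one core have so far been tested in an assay on membranes from HeLa cells for displacement of a labelled ligand from adenosine receptor A3 (Homo sapiens), read by scintillation counting, with a stated time of 180 min, tested at 1 uM; on this read-out lower numbers stand for less inhibition and higher numbers for more inhibition at the one concentration tested (going by the name of the read-out). Compound 1 `CC1=C(C(=O)OC(C)(C)C)C(c2ccsc2)NC(=O)N1` gives 1% there. Compound 2 `CC(=O)C1=C(C)NC(=O)NC1c1ccoc1` gives 2% in this assay; on the numbers shown compound 2 sits at the top, yet compound 1 lies within the scatter of it, so the two are not distinguished, and both numbers are small. Compound 3 `CC(=O)C1=C(C)NC(=O)NC1c1ccsc1` has not yet been measured; it differs from compound 2 in one place: thiophen-3-yl in place of furan-3-yl on a saturated ring carbon. For the measured compounds named here, no step between two measured compounds is available to show how such an exchange moves the read-out. The expected step is no change at the digits printed from compound 2 to compound 3 (within the scatter), none beyond the scatter, because compound 2 gives 2% and compound 1, which also carries thiophen-3-yl, gives 1%. Compound 3 is therefore estimated to give 2% in this assay, with a range from -8% to 12%.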

Compound 3, a percentage reported as inhibition, at one concentration (the size of the read-out at that concentration, not a potency): 1%
Beside the measured number, compound 3's estimate is 1 percentage points above it; the measured number falls inside the stated range.
By their numbers in this assay, from the lowest: compounds 1, 3 and 2 (each within the scatter of the next).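

In this assay, the exchange of furan-3-yl for thiophen-3-yl on the saturated ring carbon can now be read directly as a step between two measured compounds, and it amounts to a number 1 percentage points lower from compound 2 to compound 3 (within the scatter). A second exchange, methyl in place of tert-butoxy on a carbonyl carbon, can also be read, and it gives no change at the digits printed from compound 1 to compound 3 (within the scatter), so neither exchange separates the compounds at this one concentration. No other measurement here helps to interpret these two results.

On these data alone, whether a phenyl ring on the saturated ring carbon, or an amine or a longer chain on the carbonyl carbon, would move the read-out beyond the scatter remains open. As far as these compounds go, with only small numbers at a single concentration, how these compounds would compare at any other concentration also remains open.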